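Swapping methoxy for chloro in two close cousins

The source may report more compounds than this note shows. Statements on the series, on what has been measured and on what is new or still open speak of the compounds shown alone.

Of the compounds shown here, three have been tested in a functional assay on Malme-3M cells (Homo sapiens) for inhibition; a lower number here means a stronger inhibitor of growth, a higher number a weaker inhibitor of growth. Compound 1 `COc1cc(/C=C/C(=O)c2cccc(-n3cc(-c4ccc(Cl)cc4)[nH]c3=O)c2)cc(OC)c1OC` gives 18100 nM, compound 2 `COc1ccc(-c2cn(-c3cccc(C(=O)/C=C/c4ccc(O)c(OC)c4)c3)c(=O)[nH]2)cc1` gives 4420 nM, and compound 3 `COc1ccc(-c2cn(-c3cccc(C(=O)/C=C/c4cc(OC)c(OC)c(OC)c4)c3)c(=O)[nH]2)cc1` gives 1790 nM. Compound 4 `COc1cc(/C=C/C(=O)c2cccc(-n3cc(-c4ccc(Cl)cc4)[nH]c3=O)c2)ccc1O` has not yet been measured.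

Compound 4 is built from compound 2 by one change: chloro in place of methoxy on an aromatic carbon. The same change has already been made once, from compound 3 to compound 1: chloro in place of methoxy on an aromatic carbon. That earlier step was a 10-fold higher number from compound 3 to compound 1 (1.00 log units; beyond the scatter), so the chloro compound was the weaker growth inhibitor. The two places are described in the same words, so the change made to compound 2 is the same change, only on a different core. The cores of compound 2 and compound 3 differ as follows: 4-hydroxy-3-methoxyphenyl in place of 3,4,5-trimethoxyphenyl on a double-bonded chain carbon bound to a double-bonded chain carbon. In this assay that core difference was a 2.5-fold lower number from compound 2 to compound 3 (0.39 log units; beyond the scatter).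

Within the data shown here, for compound 4 the step from compound 2 is expected to be a 7.9-fold higher number from compound 2 to compound 4 (0.90 log units; beyond the scatter), a little smaller than the earlier one because a single earlier step of a 10-fold higher number from compound 3 to compound 1 (1.00 log units; beyond the scatter) is the only guide and steps of this kind are rarely repeated exactly. Because compound 2 already gives 4420 nM, compound 4 is expected to be a weak inhibitor at around 35000 nM, with a likely range from 10000 nM to 120000 nM. This rests on two compounds only, so it stays a rough expectation.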

Compound 4, concentration for 50% growth inhibition: 3060 nM
Compound 4: the middle estimate sits 11-fold (1.06 log units) above what was measured; the whole stated range lies above it.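

In this assay, replacing 4-methoxyphenyl with 4-chlorophenyl on the core that carries the 4-hydroxy-3-methoxyphenyl group gave a 1.4-fold lower number from compound 2 to compound 4 (0.16 log units; within the scatter), so on this core the swap makes no difference that can be told from ordinary assay noise. The same swap on the core that carries the 3,4,5-trimethoxyphenyl group gave a very different result, and the gap between the two outcomes is real rather than scatter: the same change on two cores in this assay, a 10-fold higher number (1.00 log units; beyond the scatter) from compound 3 to compound 1 and a 1.4-fold lower number (0.16 log units; within the scatter) from compound 2 to compound 4, 15-fold (1.16 log units) apart, beyond the scatter of two such steps. Among these compounds, this shows that the outcome of this swap in one core cannot simply be carried over to the other, so the rest of the molecule matters to what the change does, but it does not show why the two cores part ways, and with only two pairs it cannot say which outcome is the more usual one.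

The compounds shown carry only methoxy or chloro at this place, so it remains open whether a fluoro group, a methyl group or an amine there would track either pair. From the compounds shown here alone, it also remains open how a third core, such as one with an unsubstituted phenyl on the double-bonded chain, would respond to the same swap.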